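A few compounds are considered here, and "the series" means these few. Any claim that something is new, unique, unknown or untested is made for them only; others in the source may bear on it.

Compound 1 `c1ccc(CCC2=NCCN2)cc1` is one of two compounds examined in an assay on PC-12 cells for binding affinity to Nischarin (Rattus norvegicus) (a higher number here means a weaker inhibitor, a lower number a stronger inhibitor), in which compound 1 gives 3720 nM. Its only companion so far is compound 2 `c1ccc(-c2ccccc2CCC2=NCCN2)cc1`, which in this assay gives 3240 nM. For the measured compounds named here, compound 1 therefore has the highest of the two numbers, and the sole step connecting it to a measured neighbour is a 1.1-fold lower number from compound 1 to compound 2 (0.06 log units; within the scatter), a step that lies within the scatter. Compound 3 `C[C@H](CC1=NCCN1)c1ccccc1` is not yet measured; it differs from compound 1 by methyl in place of hydrogen on a saturated chain carbon bound to an aromatic carbon and a saturated chain carbon. Going by the values given here, no measured step touches that place in the shared core of compound 1, so the one step available, a 1.1-fold lower number from compound 1 to compound 2 (0.06 log units; within the scatter), bears on it only in showing that the single change tried so far on compound 1 left the number essentially unmoved. On that basis the expected step is a 1.1-fold lower number from compound 1 to compound 3 (0.03 log units; within the scatter), that is, no change beyond the scatter in either direction. Compound 3 is accordingly estimated to give about 3500 nM in this assay, with a plausible range from 1200 nM to 10000 nM.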

Compound 3, inhibition constant: 589 nM
Compound 3: middle estimate off by 5.9-fold (0.77 log units), on the high side; the measured number lies below the stated range.
By their numbers in this assay, from the lowest: compound 3; then compounds 2 and 1 (each within the scatter of the next).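

In this assay, the step of a 6.3-fold lower number from compound 1 to compound 3 (0.80 log units; beyond the scatter) shows that the saturated chain carbon bound to an aromatic carbon and a saturated chain carbon is a place where a change to compound 1 can move the number beyond the scatter, and that methyl in place of hydrogen, only 1 heavy atom, is enough to do so. The earlier step, a 1.1-fold lower number from compound 1 to compound 2 (0.06 log units; within the scatter), involved a larger group at a different place, phenyl on an aromatic carbon, and stayed within the scatter, so the two changes tried on compound 1 do not act alike in this assay. Nothing available explains why methyl at this carbon lowers the number.

The compounds shown leave open how an ethyl group, a hydroxyl group or an amine on this carbon would compare with methyl, and whether the mirror-image arrangement at this carbon would give the same number. They also leave open whether methyl at this carbon would lower the number to a similar extent in compound 2, which carries the phenyl group.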